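The source may report more compounds than this note shows. Statements on the series, on what has been measured and on what is new or still open speak of the compounds shown alone.

Compound 1 `CN(C)c1cc2[nH]c(C3CCCCC3)nc2cc1NC(=O)OCc1ccccc1`, compound 2 `CCCOCC(=O)Nc1cc2nc(C3CCCCC3)[nH]c2cc1N(C)C` and compound 3 `CN(C)c1cc2[nH]c(C3CCCCC3)nc2cc1NC(=O)c1cccs1` share one core and differ only in the group on the carbonyl carbon. In an ADME assay on Vero cells (Chlorocebus sabaeus) for cytotoxicity, read by resazurin assay, with a stated time of 3 days (a lower number here means a stronger inhibitor, a higher number a weaker inhibitor), compound 3 gives > 100 ug/mL, which is a limit of the assay and not a number. Compound 1 gives > 100 ug/mL, also a limit. Compound 2 gives < 50 ug/mL, again a limit. The measured steps read an at least 2.0-fold lower number from compound 1 to compound 2 (0.30 log units; that floor lies within the scatter) and an at least 2.0-fold higher number from compound 2 to compound 3 (0.30 log units; that floor lies within the scatter), while a step that the two limits leave unreadable from compound 1 to compound 3. Compound 4 `CN(C)c1cc2[nH]c(C3CCCCC3)nc2cc1NC(=O)c1ccc(F)cc1F` carries the change (2,4-difluorophenyl in place of thiophen-2-yl on a carbonyl carbon). Among the compounds with values here, the only measured aromatic amide, compound 3, sits at a limit in this assay, and no measured step follows such an exchange. No step beyond the scatter is therefore expected, a number no higher from compound 3 to compound 4 (the limit leaves the size open). Compound 4 is expected to give 100 ug/mL in this assay, between 50 ug/mL and 200 ug/mL.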

Compound 4, half-maximal inhibitory concentration: > 100 ug/mL
Compound 4: a limit, no number; the forecaster's own chance of this, stated with the estimate: 70%; the middle value lies on the limit itself.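

Replacing the thiophen-2-yl of compound 3 with 2,4-difluorophenyl, a six-membered aromatic ring of carbon only, gives a second aromatic amide at the upper limit of this assay: the limit of > 100 ug/mL in this assay, at which 3 of the 4 values shown sit.
Within the data shown here, the one readable step is an at least 2.0-fold higher number from compound 2 to compound 4 (0.30 log units; that floor lies within the scatter), and the steps to compound 4 from compound 1 and compound 3 cannot be read, since both ends of each are limits.

On these data alone, how far compound 1, compound 3 and compound 4 lie past that limit stays open. So does whether a group carrying an amine or a carboxylic acid on the carbonyl carbon would stay there.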